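Swapping a chlorophenyl for a chlorofluorophenyl: an expected limit

A few compounds are considered here, and "the series" means these few. Any claim that something is new, unique, unknown or untested is made for them only; others in the source may bear on it.

Measured so far:
Compound 1 `Cc1ccc(-n2nncc2CN2C(=O)C3(C(C#N)=C(N)Oc4c3c3nc5ccccc5nc3c3ccccc43)c3ccccc32)cc1C` — > 50000 nM
Compound 2 `N#CC1=C(N)Oc2c(N)cc3nc4ccccc4nc3c2C12C(=O)N(Cc1cnnn1-c1ccccc1Cl)c1ccccc12` — > 50000 nM

In an ADME assay on L02 cells (Homo sapiens) for antiproliferative activity, read by MTT assay, with a stated time of 48 h (a higher number here means a weaker inhibitor, a lower number a stronger inhibitor), compound 1 gives > 50000 nM, which is a limit of the assay rather than a number. Compound 2 likewise gives only the limit > 50000 nM. Both values sit at the limit of > 50000 nM in this assay, at which 2 of the 2 values shown sit, so compound 2 stands at the edge of what the assay can report. Compound 3 `N#CC1=C(N)Oc2c(N)cc3nc4ccccc4nc3c2C12C(=O)N(Cc1cnnn1-c1ccc(F)c(Cl)c1)c1ccccc12` differs from compound 2 by 3-chloro-4-fluorophenyl in place of 2-chlorophenyl on an aromatic nitrogen. For the measured compounds named here, no measured step covers a change of this kind, and none beyond the scatter is expected in this assay. Compound 3 is therefore expected to give 50000 nM, between 20000 nM and 100000 nM. The expected step is a number no higher from compound 2 to compound 3 (the limit leaves the size open), which is to say no real change.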

Compound 3, half-maximal inhibitory concentration: > 50000 nM
Compound 3 ended at the assay's limit; the forecaster's own chance of this, stated with the estimate: 85%; the middle value lies on the limit itself.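

For the compounds shown here, compound 2 and compound 3 each give only a limit in this assay, so no step between them can be read. The compounds shown leave open whether 3-chloro-4-fluorophenyl in place of 2-chlorophenyl changes the real strength of inhibition in this assay at all.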